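The source may report more compounds than this note shows. Statements on the series, on what has been measured and on what is new or still open speak of the compounds shown alone.

Measured compounds:
Compound 1 `Fc1cccc(Nc2nc(-c3cccc(F)c3)nc3ccc(F)cc23)c1` gives 48700 nM in a functional assay on MCF7 cells (Homo sapiens) for cytotoxicity, read by MTT assay, with a stated time of 48 h; a lower number here means a stronger inhibitor, a higher number a weaker inhibitor.
Compound 2 `Oc1ccccc1Nc1nc(-c2cccc(F)c2)nc2ccc(F)cc12` gives > 50000 nM in this assay, which is a limit of the assay, not a number.
Compound 3 `Nc1ccc(Nc2nc(-c3cccc(F)c3)nc3ccc(F)cc23)cc1` gives > 50000 nM in this assay, again a limit of the assay.

Compound 1 is thus the only one of the three with a measured number; the other two values are limits, as the limit of > 50000 nM in this assay, at which 2 of the 3 values shown sit, shows. All three compounds share the same core and differ only in the group on the nitrogen attached to it.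

Compound 4 `Nc1cccc(Nc2nc(-c3cccc(F)c3)nc3ccc(F)cc23)c1` is the unmeasured compound. It differs from compound 1 by amino in place of fluoro on an aromatic carbon, so the amino group of compound 3 is kept but moved onto the position where compound 1 carries its fluoro group.

Among the measured compounds shown here, two measured steps bear on this. The step of an at least 1.0-fold higher number from compound 1 to compound 2 (0.01 log units; that floor lies within the scatter) and the step of an at least 1.0-fold higher number from compound 1 to compound 3 (0.01 log units; that floor lies within the scatter) both sit within the scatter of repeated measurements, and the step that the two limits leave unreadable from compound 2 to compound 3 cannot be read. Every change of this kind recorded here leaves the value near or at the limit, so no step beyond the scatter is expected in this assay, and a limit is again quite possible.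

Compound 4 is therefore estimated at 55000 nM, within 25000 nM to 120000 nM, corresponding to an expected step of a 1.1-fold higher number from compound 1 to compound 4 (0.05 log units; within the scatter).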

Compound 4, half-maximal inhibitory concentration: > 50000 nM
Compound 4: no number, only a limit (the forecaster's own chance of this, stated with the estimate: 60%); the middle value is on the limit's open side.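

Compound 4 gives > 50000 nM in this assay, which is a limit of the assay and not a number. Putting amino in place of fluoro on this aromatic carbon, which adds a hydrogen-bond donor and a hydrogen-bond acceptor, gives an at least 1.0-fold higher number from compound 1 to compound 4 (0.01 log units; that floor lies within the scatter); this is only a floor, so the change is not shown to make a difference beyond the scatter, and its true size stays unknown. The steps from compound 2 and from compound 3 to compound 4 cannot be read, so the 3-aminophenyl and 4-aminophenyl groups cannot be told apart, and the set now rests mostly on a single limit: the limit of > 50000 nM in this assay, at which 3 of the 4 values shown sit.

From the compounds shown here alone, how far past that limit compound 2, compound 3 and compound 4 lie stays open, so no order among them can be given. Also open, going by these compounds, is what a methoxy group, a chlorine atom or a carboxylic acid would give on this aromatic carbon, and whether any group there would bring the value clearly lower than that of compound 1.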